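Aryl swap on the hydrazone arm: compound 2 to compound 3

This account rests on a few compounds, and the source may have more. Where it says the series, first, only, none or still open, it means among the compounds named here.

Measured so far:
- compound 1 `COc1cc2c(Oc3ccc(NC(=O)N/N=C/c4ccc(F)cc4Cl)cc3F)ccnc2cc1OCCCN1CCCCC1`: 130 nM
- compound 2 `COc1cc2c(Oc3ccc(NC(=O)N/N=C/c4ccc([N+](=O)[O-])cc4)cc3F)ccnc2cc1OCCCN1CCC(C)CC1`: 380 nM

In a functional assay on A549 cells (Homo sapiens) for cytotoxicity, read by MTT assay, with a stated time of 72 h (a higher number here means a weaker inhibitor, a lower number a stronger inhibitor), compound 2 gives 380 nM, the higher of the two numbers; compound 1 gives 130 nM, a gap beyond the scatter. Compound 3 `COc1cc2c(Oc3ccc(NC(=O)N/N=C/c4ccc(F)cc4Cl)cc3F)ccnc2cc1OCCCN1CCC(C)CC1` is not yet measured. It differs from compound 2 by 2-chloro-4-fluorophenyl in place of 4-nitrophenyl on a carbon with a double bond to nitrogen. With that aryl group compound 3 carries the same hydrazone arm as compound 1, so a lower number is expected, a step beyond the scatter, a 2.5-fold lower number from compound 2 to compound 3 (0.40 log units; beyond the scatter). Compound 3 is estimated at 150 nM, expected between 70 nM and 350 nM, because compound 1 sits at 130 nM.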

Compound 3, half-maximal inhibitory concentration: 190 nM
For compound 3 the middle estimate is 1.3-fold (0.10 log units) below the measured one; the range from low to high includes it.
By their numbers in this assay, from the lowest: compounds 1, 3 and 2 (each within the scatter of the next, the first and the last beyond it).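

In this assay, 2-chloro-4-fluorophenyl in place of 4-nitrophenyl on a carbon with a double bond to nitrogen gives a step within the scatter (a 2.0-fold lower number from compound 2 to compound 3 (0.30 log units; within the scatter)), so this pair does not separate the two aryl groups. Methyl in place of hydrogen on a saturated ring carbon also stays within the scatter (a 1.5-fold higher number from compound 1 to compound 3 (0.16 log units; within the scatter)). No measurement on hand accounts for either step.

Still open, going by these compounds, is whether an amine or a carboxylic acid on this aryl ring would give a step beyond the scatter. The same question applies to a longer chain in place of the methyl.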